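From 2,3-dichlorophenyl to 2,4-dichlorophenyl: working notes

A few compounds are considered here, and "the series" means these few. Any claim that something is new, unique, unknown or untested is made for them only; others in the source may bear on it.

Compounds measured so far in an ADME assay on MT4 cells (Homo sapiens) for cytotoxicity, read by MTT assay; a higher number here means that more compound is tolerated, a lower number that less compound is tolerated
- Compound 1 `Cc1ccccc1C(=O)N(C(=S)OCCN1C(=O)c2ccccc2C1=O)c1ccc(Cl)cc1` gives 21000 nM
- Compound 2 `O=C1c2ccccc2C(=O)N1CCOC(=S)N(C(=O)c1cc(F)ccc1F)c1ccc(Cl)cc1` gives 54000 nM
- Compound 3 `O=C1c2ccccc2C(=O)N1CCOC(=S)N(C(=O)c1cccc(Cl)c1Cl)c1ccc(Cl)cc1` gives 54000 nM

Compound 3 stands level with compound 2 (no change at the digits printed from compound 2 to compound 3 (within the scatter)), and the two share the top of the three numbers. Compound 1 lies lower, as the measured step shows (a 2.6-fold higher number from compound 1 to compound 3 (0.41 log units; beyond the scatter)).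

The next structure is compound 4 `O=C1c2ccccc2C(=O)N1CCOC(=S)N(C(=O)c1ccc(Cl)cc1Cl)c1ccc(Cl)cc1`, with 2,4-dichlorophenyl in place of 2,3-dichlorophenyl on a carbonyl carbon. The two have the same atoms, joined differently.

For the measured compounds named here, two measured steps bear on this change. The exchange of one substituted phenyl for another between halogen-bearing compounds moved nothing (no change at the digits printed from compound 2 to compound 3 (within the scatter)), while the modest step seen from compound 1 involved leaving 2-methylphenyl (a 2.6-fold higher number from compound 1 to compound 2 (0.41 log units; beyond the scatter)), which does not happen here. Going by the values given here, no compound with 2,4-dichlorophenyl has been measured yet. On the evidence of compound 2 and compound 3, no step beyond the scatter is expected in this assay (a 1.1-fold lower number from compound 3 to compound 4 (0.03 log units; within the scatter)). For compound 4 the estimated value is 50000 nM, with an expected range from 25000 nM to 95000 nM in this read-out.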

Compound 4, half-maximal cytotoxic concentration: 18000 nM
Compound 4: middle estimate off by 2.8-fold (0.44 log units), on the high side; the measured number lies below the stated range.
By their numbers in this assay, from the lowest: compounds 4 and 1 (each within the scatter of the next); then compounds 2 and 3 (each within the scatter of the next).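

In this assay, the arrangement of the two chlorines on the aryl group at the carbonyl carbon matters: with the same atoms, 2,4-dichlorophenyl in place of 2,3-dichlorophenyl gives a step (a 3.0-fold lower number from compound 3 to compound 4 (0.48 log units; beyond the scatter)), whereas the earlier exchange between halogen-bearing compounds moved nothing. The same step appears against 2,5-difluorophenyl (a 3.0-fold lower number from compound 2 to compound 4 (0.48 log units; beyond the scatter)), while 2,4-dichlorophenyl stays within the scatter of 2-methylphenyl (a 1.2-fold lower number from compound 1 to compound 4 (0.07 log units; within the scatter)), so compound 4 goes against any reading that halogen-bearing aryl groups share the higher numbers. No measurement at hand speaks to the origin of this difference.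

From the compounds shown here alone, it remains open whether an aryl group carrying a single chlorine, an amine or a carboxylic acid would sit with compound 3 or with compound 4. Going by these compounds, it is also open whether the step between the two dichlorophenyl groups would persist on a core with a longer chain.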